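Para substituent swap on the benzylpiperazine amide series

A few compounds are considered here, and "the series" means these few. Any claim that something is new, unique, unknown or untested is made for them only; others in the source may bear on it.

Measured compounds:
compound 1, `Cn1c(-c2ccc(NC(=O)CN3CCN(c4ccccc4)CC3)cc2)nc(-c2ccccc2)c1-c1ccccc1`, 55.4%
compound 2, `COc1ccc(CN2CCN(CC(=O)Nc3ccc(-c4nc(-c5ccccc5)c(-c5ccccc5)n4C)cc3)CC2)cc1`, 21.8%

Both compounds share the same core and differ only at the amine nitrogen in the ring. In a functional assay on HT-29 cells (Homo sapiens) for cytotoxicity, read by MTT assay, with a stated time of 24 h, tested at 16 ug/mL (on this read-out lower numbers stand for a weaker effect and higher numbers for a stronger effect at the one concentration tested), compound 1 gives 55.4%, and compound 2 gives 21.8%, the lowest of the two numbers shown. Among the compounds with values here, the one measured step, a number 33.6 percentage points lower from compound 1 to compound 2 (beyond the scatter), is large and beyond the scatter, so changes at this position clearly register on the read-out.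

Compound 3, `Cn1c(-c2ccc(NC(=O)CN3CCN(Cc4ccc(Cl)cc4)CC3)cc2)nc(-c2ccccc2)c1-c1ccccc1`, keeps the benzyl arrangement of compound 2 and alters only its substituent: chloro in place of methoxy on an aromatic carbon. Within the data shown here, no measured step covers this kind of exchange; the step from compound 1 to compound 2 swaps the whole group rather than the para substituent, so it bears only loosely here. With nothing closer to go on, the estimate for compound 3 stays near compound 2, with wide bounds. Compound 3 is estimated at 28%, range 10% to 50%, an expected step of a number 6.2 percentage points higher from compound 2 to compound 3 (within the scatter).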

Compound 3, a percentage reported as activity, at one concentration (the size of the read-out at that concentration, not a potency): 52.9%
Estimate against measurement, compound 3: 24.9 percentage points below; measured number above the stated range.
By their numbers in this assay, from the lowest: compound 2; then compounds 3 and 1 (each within the scatter of the next).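

In this assay the substituent on the benzyl group alone carries a large effect, with a number 31.1 percentage points higher from compound 2 to compound 3 (beyond the scatter) for chloro in place of methoxy on an aromatic carbon, para to a large group. The low number of compound 2 therefore does not extend to every benzyl group: 4-chlorobenzyl in place of phenyl on the ring nitrogen gives a number 2.5 percentage points lower from compound 1 to compound 3 (within the scatter) so on this read-out compound 3 and compound 1 cannot be told apart. No evidence at hand bears on the reason for this result.

The compounds shown leave open whether the step follows from the presence of chloro or from the absence of methoxy; an unsubstituted benzyl, 4-fluorobenzyl or 4-methylbenzyl group would separate these readings. A read-out at one concentration also gives no potency for any of these compounds.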